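The source may hold more compounds than are shown below. What is called first, only, known or untested is meant among the compounds shown, and "the series" means these compounds.

Working notes on a small set of compounds built on one shared core and tested in an assay on isolated protein for inhibition of thyroid hormone receptor beta (Homo sapiens), read by fluorescence polarization; a higher number here means a weaker inhibitor, a lower number a stronger inhibitor. Compound 1 `CS(=O)(=O)c1ccc(C(=O)N2CCC(C(=O)N3CCc4ccccc43)CC2)cc1[N+](=O)[O-]` reaches only a limit of that assay: in this assay compound 1 gives > 60000 nM, a limit and not a number. Compound 2 `Cc1ccc(N2CCN(C(=O)C3CCN(C(=O)c4ccc(S(C)(=O)=O)c([N+](=O)[O-])c4)CC3)CC2)cc1` also stops at a limit, giving > 60000 nM in this assay. For the measured compounds named here, compound 3 `CN(Cc1ccccc1)C(=O)CNC(=O)c1ccc(S(C)(=O)=O)c([N+](=O)[O-])c1` is the one member with an actual number, giving 39000 nM in this assay. Compound 1 therefore stands at the limit of > 60000 nM in this assay, at which 2 of the 3 values shown sit, and nothing in the set places it apart from compound 2.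

Compound 4 `CC1Cc2ccccc2N1C(=O)C1CCN(C(=O)c2ccc(S(C)(=O)=O)c([N+](=O)[O-])c2)CC1` differs from compound 1 by methyl in place of hydrogen on a saturated ring carbon, in words methyl in place of hydrogen on a saturated ring carbon, with the rest of the core untouched. Going by the values given here, no step between two measured compounds is available to gauge a change of this kind, and compound 1 offers only a limit to start from. The step is expected to be a step that the limit leaves unreadable from compound 1 to compound 4, none beyond the usual scatter. Compound 4 is accordingly expected to give about 80000 nM, within 20000 nM to 300000 nM, most likely returned again only as a limit.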

Compound 4, half-maximal inhibitory concentration: > 60000 nM
Compound 4 ended at the assay's limit; the forecaster's own chance of this, stated with the estimate: 85%; the middle value does not contradict the limit.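

Compound 4 gives > 60000 nM, a limit and not a number. For the compounds shown here, compound 1 also stands at a limit, so no step from compound 1 to compound 4 can be read. The compounds shown leave open whether methyl in place of hydrogen on a saturated ring carbon changes inhibition at all.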